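This account rests on a few compounds, and the source may have more. Where it says the series, first, only, none or still open, it means among the compounds named here.

Measured so far: compound 1 `CCc1ccc(N(Cc2ccccc2)S(=O)(=O)c2ccc3c(c2)C(=O)CC(C2CCOCC2)O3)cc1` with 4.84; compound 2 `CC(C)CN(c1ccc(F)cc1F)S(=O)(=O)c1ccc2c(c1)C(=O)CC(C1CCOCC1)O2` with 3.62; compound 3 `CC(C)CN(c1cccc(F)c1)S(=O)(=O)c1ccc2c(c1)C(=O)CC(C1CCOCC1)O2` with 3.5.

In a physicochemical assay for lipophilicity, at pH 7.4 (a higher number here means a more lipophilic compound, a lower number a more polar compound), compound 1 stands highest of the three, beyond the scatter from compound 2 and compound 3. Compound 4 `CCc1ccc(NS(=O)(=O)c2ccc3c(c2)C(=O)CC(C2CCOCC2)O3)cc1` is not yet measured. Its change from compound 1 is hydrogen in place of benzyl on a sulfonamide nitrogen. Among the measured compounds shown here, the only measured step, a number 0.12 log units lower from compound 2 to compound 3 (within the scatter), concerns the aryl group on the nitrogen and lies within the scatter; no measured step changes the group on the sulfonamide nitrogen itself. The removal of a seven-carbon group is nonetheless expected to lower the number by a clear margin: compound 4 is estimated at 3 (range 2.4 to 3.6), a step of a number 1.84 log units lower from compound 1 to compound 4 (beyond the scatter).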

Compound 4, distribution coefficient: 2.67
Estimate against measurement, compound 4: 0.33 log units above, within the range that was stated.
By their numbers in this assay, from the lowest: compound 4; then compounds 3 and 2 (each within the scatter of the next); then compound 1.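

In this assay, the group on the sulfonamide nitrogen proves to be a place where a single change moves the number beyond the scatter: hydrogen in place of benzyl gives a number 2.17 log units lower from compound 1 to compound 4 (beyond the scatter) in this series. Among the compounds shown here, the only earlier step, a number 0.12 log units lower from compound 2 to compound 3 (within the scatter), changed the aryl group on that nitrogen and not the group replaced here. Nothing shown gives a measured reason for the size of this new step.

The compounds shown leave open how the number would respond to something intermediate on that nitrogen. A methyl group, a 2-aminoethyl chain or an acetic acid group there remains an open case.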